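Working notes on cytotoxicity across four related compounds

The source may report more compounds than this note shows. Statements on the series, on what has been measured and on what is new or still open speak of the compounds shown alone.

Compound 1 `C=C[C@@](C)(/C=C/c1ccc(O)c(/C=C/C(=O)OCC)c1)CCC=C(C)C` was examined in a functional assay on HepG2 cells (Homo sapiens) for cytotoxicity, with a stated time of 72 h; on this read-out higher numbers stand for an effect only at larger amounts of compound and lower numbers for an effect already at smaller amounts. In this assay compound 1 gives > 52000 nM, which is a limit of the assay and not a number. Compound 2 `C=C[C@@](C)(/C=C/c1ccc(O)c(/C=C(\C)C(=O)OCC)c1)CCC=C(C)C` differs from compound 1 by 2-(ethoxycarbonyl)prop-1-en-1-yl in place of 2-(ethoxycarbonyl)ethenyl on an aromatic carbon. In this assay compound 2 gives > 52000 nM, again a limit. For the measured compounds named here, the step that the two limits leave unreadable from compound 1 to compound 2 is therefore not readable; the only evidence for it is the limit of > 52000 nM in this assay, at which 3 of the 3 values shown sit. Compound 3 `CCOC(=O)/C=C/c1cc(/C=C/[C@](C)(/C=C/c2ccc(OC)cc2)CCC=C(C)C)ccc1O` differs from compound 1 by 2-(4-methoxyphenyl)ethenyl in place of vinyl on a saturated chain carbon bound to a double-bonded chain carbon and two saturated chain carbons, and this is also the difference between the core of compound 3 and the core of compound 1 as it carries over to compound 4. In this assay compound 3 gives > 52000 nM, once more a limit. The step that the two limits leave unreadable from compound 1 to compound 3 is likewise left unreadable by the two limits.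

Compound 4 `CCOC(=O)/C(C)=C/c1cc(/C=C/[C@](C)(/C=C/c2ccc(OC)cc2)CCC=C(C)C)ccc1O` has not yet been measured in this assay. It differs from compound 3 by 2-(ethoxycarbonyl)prop-1-en-1-yl in place of 2-(ethoxycarbonyl)ethenyl on an aromatic carbon, the same change as that from compound 1 to compound 2, made on the same place in words and on the other core. The expected step from compound 3 to compound 4 is a step that the limit leaves unreadable from compound 3 to compound 4, an estimate that rests on the measured step that the two limits leave unreadable from compound 1 to compound 2 and on (the limit of > 52000 nM in this assay, at which 3 of the 3 values shown sit). Compound 4 is accordingly estimated at 60000 nM, with a range from 30000 nM to 150000 nM, and the outcome is expected to be reported as a limit rather than a number.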

Compound 4, half-maximal effective concentration: > 52000 nM
Compound 4 ended at the assay's limit (the forecaster's own chance of this, stated with the estimate: 85%); the middle value is on the limit's open side.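

No new step can be read for compound 4 against compound 3 or compound 2, since compound 1, compound 2, compound 3 and compound 4 all end at one value that is a limit of the assay and not a number: the limit of > 52000 nM in this assay, at which 4 of the 4 values shown sit.

The compounds shown leave open how far past that limit each one lies, and whether either change alters the read-out in this assay at all.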